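From Dimethoxyphenyl to Piperazine on a Shared Core

This account rests on a few compounds, and the source may have more. Where it says the series, first, only, none or still open, it means among the compounds named here.

In a functional assay on HepG2 cells (Homo sapiens) for inhibition, read by MTT assay, with a stated time of 72 h (on this read-out higher numbers stand for weaker inhibition and lower numbers for stronger inhibition), compound 1 `CC(C)(C)n1cc2c(n1)C(=O)CC1(CCN(C(=O)c3cc(-c4ccccc4Cl)nc4ccccc34)CC1)O2` gives > 10000 nM as a limit of the assay and not a number. Among the measured compounds shown here, compound 2 `COc1ccc(-c2cc(C(=O)N3CCC4(CC3)CC(=O)c3nn(C(C)(C)C)cc3O4)c3ccccc3n2)cc1OC` stands at 1560 nM as the only exact value so far. Compound 3 `CC(C)(C)n1cc2c(n1)C(=O)CC1(CCN(C(=O)c3cc(N4CCNCC4)nc4ccccc34)CC1)O2` carries piperazin-1-yl in place of 3,4-dimethoxyphenyl on an aromatic carbon next to the ring nitrogen (piperazin-1-yl in place of 3,4-dimethoxyphenyl on an aromatic carbon). For the measured compounds named here, the one measured step at this carbon, 3,4-dimethoxyphenyl in place of 2-chlorophenyl, gave an at least 6.4-fold lower number from compound 1 to compound 2 (0.80 log units; beyond the scatter) with the limit of > 10000 nM in this assay, at which 1 of the 2 values shown sits, leaving its full size open, so the group here can move the number. A modest change toward weaker inhibition is expected in this assay with a 1.9-fold higher number from compound 2 to compound 3 (0.28 log units; within the scatter) as the estimated step. Compound 3 is estimated at 3000 nM within a range of 700 nM to 10000 nM overall.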

Compound 3, half-maximal inhibitory concentration: 8570 nM
The estimate for compound 3 lay 2.9-fold (0.46 log units) below the measured number, within the range that was stated.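

In this assay, among the compounds shown here, this is the first step at this carbon that replaces a six-membered aromatic ring of carbon only with a non-aromatic ring, and piperazin-1-yl in place of 3,4-dimethoxyphenyl gives a 5.5-fold higher number from compound 2 to compound 3 (0.74 log units; beyond the scatter). Against 2-chlorophenyl, piperazin-1-yl gives an at least 1.1-fold lower number from compound 1 to compound 3 (0.06 log units; that floor lies within the scatter), so no order of these two groups can be read, as compound 1 holds a limit and not a number: the limit of > 10000 nM in this assay, at which 1 of the 3 values shown sits.

The compounds shown leave open how morpholin-4-yl or 4-methylpiperazin-1-yl would read at this carbon. They also leave open whether a phenyl ring with a single methoxy group would match compound 2.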